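The compounds below may be only part of what the source reports. "The series", "measured", "known", "first", "only" and "open" are said of these compounds alone.

Measured compounds in a physicochemical assay for solubility, in phosphate buffer, measured as kinetic solubility, with a stated time of 18 h, at pH 7.4; a lower number here means a less soluble compound, a higher number a more soluble compound:
compound 1 `CN(C)CCC(=O)Nc1cccc(-c2nc3ccccc3s2)c1`: 56000 nM
compound 2 `O=C(CCl)Nc1cccc(-c2nc3ccccc3s2)c1`: 1000 nM
compound 3 `O=C(Nc1cccc(-c2nc3ccccc3s2)c1)c1ccc(Cl)nc1Cl`: 350 nM

Compound 1 stands highest of the three numbers in this assay. The nearest is compound 2, with a 56-fold lower number from compound 1 to compound 2 (1.75 log units; beyond the scatter); the furthest is compound 3, with a 160-fold lower number from compound 1 to compound 3 (2.20 log units; beyond the scatter). Between the two amides with a carbon substituent other than the aminoalkyl chain, the step of a 2.9-fold lower number from compound 2 to compound 3 (0.46 log units; beyond the scatter) is modest.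

Compound 4 `O=C(Nc1cccc(-c2nc3ccccc3s2)c1)c1ccncc1Cl` has not been measured in this assay. Its change from compound 1 is 3-chloropyridin-4-yl in place of 2-(dimethylamino)ethyl on a carbonyl carbon. Going by the values given here, the step that bears on it most directly is the one from compound 1 to compound 3, where a chloro-substituted pyridinyl group likewise replaces the 2-(dimethylamino)ethyl chain on the carbonyl carbon and the number falls by a large amount. The step from compound 1 to compound 2 points the same way, also large. A large drop in this assay is therefore expected for compound 4, with the result placed between those of compound 2 and compound 3. The expected step is a 70-fold lower number from compound 1 to compound 4 (1.85 log units; beyond the scatter). Compound 4 is estimated at 800 nM, with a range from 250 nM to 2500 nM.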

Compound 4, solubility: 320 nM
Compound 4: the middle estimate sits 2.5-fold (0.40 log units) above what was measured, and the stated range covers the measured number.
By their numbers in this assay, from the lowest: compounds 4 and 3 (each within the scatter of the next); then compound 2; then compound 1.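

In this assay the 3-chloropyridin-4-yl group on the carbonyl carbon gives a 180-fold lower number from compound 1 to compound 4 (2.24 log units; beyond the scatter) in place of 2-(dimethylamino)ethyl, so the large fall seen with one chloropyridinyl amide recurs with a second, differently substituted one. The step of a 1.1-fold lower number from compound 3 to compound 4 (0.04 log units; within the scatter) does not separate 3-chloropyridin-4-yl from 2,6-dichloropyridin-3-yl at this position, so the change of ring substitution between these two amides leaves no readable difference. Replacing chloromethyl gives a 3.1-fold lower number from compound 2 to compound 4 (0.49 log units; beyond the scatter) and is modest beside the fall from compound 1, with both pyridinyl amides on the same side of compound 2.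

Still open, from the compounds shown here alone, is whether a pyridinyl amide carrying a dimethylamino group or a carboxylic acid would come back toward compound 1 at 56000 nM in this assay. No measurement among the compounds shown offers an account of these steps.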